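The source may hold more compounds than are shown below. What is called first, only, known or untested is meant among the compounds shown, and "the series" means these compounds.

In a functional assay on ECa-109 cells for inhibition, with ECa-109 cell line (Homo sapiens) as the target, read by sulforhodamine B assay (on this read-out higher numbers stand for weaker inhibition and lower numbers for stronger inhibition), compound 1 (`O=C1C=C(Nc2cccc(F)c2)C(=O)c2c1nc1n2[C@H]2OC[C@@H](O)[C@H]2OC1`) gives 7030 nM and compound 2 (`O=C1C=C(Nc2cccc(Cl)c2)C(=O)c2c1nc1n2[C@H]2OC[C@@H](O)[C@H]2OC1`) gives 4690 nM, so compound 2 stands level with compound 1 within the scatter. Compound 3 (`O=C1C=C(N2CCCC2)C(=O)c2c1nc1n2[C@H]2OC[C@@H](O)[C@H]2OC1`) is not yet measured. Its change from compound 2 is pyrrolidin-1-yl in place of (3-chlorophenyl)amino on a double-bonded ring carbon. Within the data shown here, the only measured step, a 1.5-fold lower number from compound 1 to compound 2 (0.18 log units; within the scatter), is chloro in place of fluoro on an aromatic carbon, and it stays within the scatter. Among the measured compounds shown here, no measured step replaces the whole group, so no step beyond the scatter can be confidently expected in this assay, in either direction. The estimated change is a 1.3-fold higher number from compound 2 to compound 3 (0.11 log units; within the scatter). For compound 3 the expected value is 6000 nM, within an estimated range of 1500 nM to 24000 nM.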

Compound 3, half-maximal inhibitory concentration: > 16000 nM
Compound 3 ended at the assay's limit; the forecaster's own chance of this, stated with the estimate: 10%; at least 2.6-fold (0.42 log units) between middle value and limit.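

In this assay compound 3 reads only as a limit of the assay, not as a number: the limit of > 16000 nM in this assay, at which 1 of the 3 values shown sits.

Even so, this position now shows a change beyond the scatter, which the chloro for fluoro swap did not: pyrrolidin-1-yl in place of the anilino groups gives an at least 3.4-fold higher number from compound 2 to compound 3 (0.53 log units; beyond the scatter) and an at least 2.2-fold higher number from compound 1 to compound 3 (0.35 log units; beyond the scatter). The (3-chlorophenyl)amino and (3-fluorophenyl)amino groups therefore hold inhibition that pyrrolidin-1-yl does not.

The compounds shown leave open whether the aromatic ring or the hydrogen-bond donor matters. A cyclopentylamino group and a methyl(phenyl)amino group would separate the two.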